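From 4-hydroxyphenyl to 3-methoxyphenyl on a shared core

The compounds below may be only part of what the source reports. "The series", "measured", "known", "first", "only" and "open" are said of these compounds alone.

Of the compounds shown here, two with the same core have been tested in a functional assay on SGC-7901 cells (Homo sapiens) for antiproliferative activity, read by MTT assay, with a stated time of 72 h; a higher number here means a weaker inhibitor, a lower number a stronger inhibitor. Compound 1 `COc1cc(-n2cnc3ccc(-c4cccc(F)c4)cc32)cc(OC)c1OC`, which carries a 3-fluorophenyl group, gives 2490 nM. Compound 2 `COc1cc(-n2cnc3ccc(-c4ccc(O)cc4)cc32)cc(OC)c1OC`, which carries a 4-hydroxyphenyl group, gives > 10000 nM. That value is a limit of the assay and not a number, so compound 2 has no exact position on the scale.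

Compound 3 `COc1cccc(-c2ccc3ncn(-c4cc(OC)c(OC)c(OC)c4)c3c2)c1` has 3-methoxyphenyl in place of 4-hydroxyphenyl on an aromatic carbon, and the count of that change reads (3-methoxyphenyl in place of 4-hydroxyphenyl on an aromatic carbon). Among the compounds with values here, only one measured step bears on this, and it is an at least 4.0-fold higher number from compound 1 to compound 2 (0.60 log units; beyond the scatter). It swaps a different group at the same place, and it is thin support on its own. Read in reverse, it suggests that leaving the 4-hydroxyphenyl group could bring a move of similar size toward a lower number in this assay, and thus a stronger inhibitor. The expected change is an at least 3.3-fold lower number from compound 2 to compound 3 (0.52 log units; beyond the scatter). For compound 3, the estimated value is 3000 nM, with an expected range from 900 nM to 10000 nM.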

Compound 3, half-maximal inhibitory concentration: 3310 nM
Beside the measured number, compound 3's estimate is 1.1-fold (0.04 log units) below it; the measured number falls inside the stated range.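

In this assay, the change from 4-hydroxyphenyl to 3-methoxyphenyl gives an at least 3.0-fold lower number from compound 2 to compound 3 (0.48 log units; beyond the scatter), so a second group now shows that this position of the shared core responds to what it carries. Methoxy in place of fluoro gives a 1.3-fold higher number from compound 1 to compound 3 (0.12 log units; within the scatter), which lies within the scatter, so 3-fluorophenyl and 3-methoxyphenyl cannot be told apart here, and among these three compounds only the 4-hydroxyphenyl group stands apart from the other two. How large the step from the hydroxy compound really is stays unknown, because compound 2 has a limit of the assay and not a number: the limit of > 10000 nM in this assay, at which 1 of the 3 values shown sits.

Since 4-hydroxyphenyl and 3-methoxyphenyl differ both in the group they carry and in where it sits on the phenyl ring, these compounds cannot say whether the hydroxy group itself or its place on the ring goes with the weaker result. They also leave open how this position would respond to an amine or a carboxylic acid on that phenyl ring, and whether any group there could give a much lower number than the values seen so far.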